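The compounds below may be only part of what the source reports. "The series", "measured", "known", "first", "only" and "open" are said of these compounds alone.

Working notes on the series. Compound 1 `Nc1scc(CN2CCC(c3ccc(Cl)cc3)CC2)c1C(=O)c1ccc(Cl)cc1` and compound 2 `Nc1scc(CN2CCN(C3CCCCCC3)CC2)c1C(=O)c1ccc(Cl)cc1` share a common core and are both measured in a functional assay on CHO cells with adenosine receptor A1 (Homo sapiens) as the target, read by cAMP accumulation and immunoassay, with a stated time of 6 min, tested at 1 uM; on this read-out higher numbers stand for a weaker effect at the one concentration tested and lower numbers for a stronger effect. In this assay compound 1 gives -24%, and in the same read-out compound 2 gives 3.7%. Of the two numbers in hand, compound 2 stands at the higher one. The gap between compound 2 and compound 1 lies beyond the usual scatter of repeated runs.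

The next compound is compound 3 `Nc1scc(CN2CCN(c3ccc(Cl)c(Cl)c3)CC2)c1C(=O)c1ccc(Cl)cc1`, which differs from compound 2 in one place: 3,4-dichlorophenyl in place of cycloheptyl on an amine nitrogen in a ring. Within the data shown here, no pair of measured compounds shows this kind of exchange, so there is no measured step on which to rest the expectation. Among the measured compounds shown here, with only two numbers available, the expected step of a number 11.7 percentage points lower from compound 2 to compound 3 (beyond the scatter) is downward but modest, close to the edge of the scatter. For compound 3 in this assay the estimate is -8%, with a range from -40% to 22%.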

Compound 3, a percentage reported as activity, at one concentration (the size of the read-out at that concentration, not a potency): -60%
The estimate for compound 3 lay 52 percentage points above the measured number; the measured number lies below the stated range.
By their numbers in this assay, from the lowest: compound 3; then compound 1; then compound 2.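

In this assay, 3,4-dichlorophenyl in place of cycloheptyl on the amine nitrogen in the ring gives a number 63.7 percentage points lower from compound 2 to compound 3 (beyond the scatter), a large step and the first one measured at this position. The effect at the one concentration tested therefore depends strongly on the group held here, with the six-membered aromatic ring bearing two chlorine atoms giving the stronger effect of this pair. Nothing in hand bears on the reason for a step of this size.

This single exchange alters the ring and adds chlorine together, so it leaves open how much of the step belongs to each, a question that unsubstituted phenyl or 4-chlorophenyl on the same nitrogen would address. Also open, going by these compounds, is how this position responds to a group of another kind, such as a carboxylic acid or a longer alkyl chain.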